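Moving the two methyl groups on the aryl ether

This account rests on a few compounds, and the source may have more. Where it says the series, first, only, none or still open, it means among the compounds named here.

Values measured so far in an ADME assay on MT4 cells (Homo sapiens) for cytotoxicity, read by MTT assay, with a stated time of 5 days (on this read-out higher numbers stand for lower toxicity in this test and lower numbers for higher toxicity in this test), are these
Compound 1 `Cc1cc(C)cc(Oc2cc(Nc3ccc(C#N)cc3)[nH]c(=O)c2I)c1` gives 24000 nM
Compound 2 `Cc1cc(C#N)cc(C)c1Oc1cc(Nc2ccc(C#N)cc2)[nH]c(=O)c1Cl` gives > 319000 nM as a limit of the assay and not a number
Compound 3 `Cc1cccc(C)c1Oc1cc(Nc2ccc(C#N)cc2)[nH]c(=O)c1Cl` gives 29000 nM

Among the measured compounds shown here, compound 3 at 29000 nM lies within the scatter of compound 1, the only other exact number. Compound 4 `Cc1cc(C)cc(Oc2cc(Nc3ccc(C#N)cc3)[nH]c(=O)c2Cl)c1` is related to compound 3 by 3,5-dimethylphenyl in place of 2,6-dimethylphenyl on an oxygen on an aromatic ring with 3,5-dimethylphenyl in place of 2,6-dimethylphenyl on an oxygen on an aromatic ring. For the measured compounds named here, the one measured step of an at least 11-fold lower number from compound 2 to compound 3 (1.04 log units; beyond the scatter) is large and beyond the scatter, but it is hydrogen in place of cyano on an aromatic carbon and so does not measure this change. The closer guide is compound 1, which already carries 3,5-dimethylphenyl on that oxygen and gives 24000 nM in this assay without leaving the range of compound 3. No step beyond the scatter is therefore expected. The expected change is a 1.2-fold lower number from compound 3 to compound 4 (0.06 log units; within the scatter) in this assay and is estimated to stay within the scatter. For compound 4 the estimated value is 25000 nM with an expected range from 10000 nM to 65000 nM in this test.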

Compound 4, half-maximal cytotoxic concentration: 21000 nM
The estimate for compound 4 lay 1.2-fold (0.08 log units) above the measured number, and the stated range covers the measured number.
By their numbers in this assay, from the lowest: compounds 4, 1 and 3 (each within the scatter of the next). At a limit, above all of these: compound 2.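

In this assay, 3,5-dimethylphenyl in place of 2,6-dimethylphenyl on the oxygen gives no step beyond the scatter: a 1.4-fold lower number from compound 3 to compound 4 (0.14 log units; within the scatter). Chloro in place of iodo on an aromatic carbon, read here with 3,5-dimethylphenyl on that oxygen, also stays within the scatter: a 1.1-fold lower number from compound 1 to compound 4 (0.06 log units; within the scatter). Compounds 1, 3 and 4 therefore form one group within the scatter, and neither the placing of the two methyl groups nor this change of halogen separates them on this read-out.

As far as these compounds go, compound 2 stands at a limit of the assay and not at a number: the limit of > 319000 nM in this assay, at which 1 of the 4 values shown sits. It remains open whether an amine or a carboxylic acid on the aryl ether would shift the read-out beyond the scatter, and what a nitrile would do on the 3,5-dimethylphenyl ring.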